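Alkyne amides: methoxypyridinyl in place of ethoxyphenyl

The source may hold more compounds than are shown below. What is called first, only, known or untested is meant among the compounds shown, and "the series" means these compounds.

In a functional assay on TREX cells for negative allosteric modulation of metabotropic glutamate receptor 3 (Rattus norvegicus), read by calcium flux, with a stated time of 2.5 min (a lower number here means a stronger inhibitor, a higher number a weaker inhibitor), compound 2 `CCOc1ccc(C#Cc2ccc(C(=O)N3CCC[C@@H](CO)C3)cc2)cc1` gives > 10000 nM, which is a limit of the assay and not a number. Compound 1 `O=C(c1ccc(C#Cc2ccc(Oc3ccccc3)cc2)cc1)N1CCC[C@@H](CO)C1` gives > 10000 nM in this assay, likewise a limit. Compound 3 `O=C(c1ccc(C#Cc2ccc(OC(F)(F)F)cc2)cc1)N1CCC[C@@H](CO)C1` gives > 10000 nM, again a limit. Compound 2 thus stands at the limit, and so do the two further values shown: the limit of > 10000 nM in this assay, at which 3 of the 3 values shown sit.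

The steps between the measured compounds carry no readable size: a step that the two limits leave unreadable from compound 1 to compound 2, a step that the two limits leave unreadable from compound 1 to compound 3 and a step that the two limits leave unreadable from compound 2 to compound 3. Each of them changes only the group on the oxygen on the aromatic ring, and each is hidden by the limits on both sides.

Compound 4 `COc1ccc(C#Cc2ccc(C(=O)N3CCC[C@@H](CO)C3)cc2)cn1` differs from compound 2 by 6-methoxypyridin-3-yl in place of 4-ethoxyphenyl on a triple-bonded carbon. No measured step bears on this change with a size, so no direction beyond the scatter can be expected from the shown values. In this assay the step from compound 2 to compound 4 is expected to be a step that the limit leaves unreadable from compound 2 to compound 4. Compound 4 is estimated at 15000 nM, ranging from 4000 nM to 60000 nM, and is expected most likely to return a limit again.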

Compound 4, half-maximal inhibitory concentration: > 10000 nM
Compound 4 gave a limit, no number (the forecaster's own chance of this, stated with the estimate: 75%); the middle value does not contradict the limit.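

In this assay compound 4 gives > 10000 nM, a limit and not a number, and compound 2 also stands at a limit, so no step between compound 2 and compound 4 can be read: the limit of > 10000 nM in this assay, at which 4 of the 4 values shown sit.

The compounds shown leave open whether any of these group changes alters inhibition, and by how much.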